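Aryl and phenethyl thioethers: from compound 3 to compound 4

A few compounds are considered here, and "the series" means these few. Any claim that something is new, unique, unknown or untested is made for them only; others in the source may bear on it.

Measured in a functional assay on HCT-116 cells (Homo sapiens) for inhibition, read by CCK-8 assay, with a stated time of 72 h, tested at 8 uM; on this read-out lower numbers stand for less inhibition of growth and higher numbers for more inhibition of growth at the one concentration tested:
compound 1 `Cc1ccc(SCc2ccc(C(=O)Nc3ccccc3N)cc2)cc1`: 84%
compound 2 `Nc1ccccc1NC(=O)c1ccc(CSc2ccc(Br)cc2)cc1`: 67.7%
compound 3 `Nc1ccccc1NC(=O)c1ccc(CSCCc2ccccc2)cc1`: 81.3%

Compound 3 gives 81.3%, second of the three numbers. Its place rests on two steps: a number 2.7 percentage points lower from compound 1 to compound 3 (within the scatter), and a number 13.6 percentage points higher from compound 2 to compound 3 (beyond the scatter).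

The next change leads to compound 4 `Nc1ccccc1NC(=O)c1ccc(CSc2ccc(Cl)cc2)cc1`, with 4-chlorophenyl in place of phenethyl on a sulfur.

Going by the values given here, no measured step makes this exact exchange. The two closest exchange phenethyl with another aryl group, and here they are read in reverse. The 4-bromophenyl case shows a clear gap, with a number 13.6 percentage points higher from compound 2 to compound 3 (beyond the scatter), while the 4-methylphenyl case shows none, with a number 2.7 percentage points lower from compound 1 to compound 3 (within the scatter). The exchange of methyl for bromo on the aromatic ring also matters, with a number 16.3 percentage points lower from compound 1 to compound 2 (beyond the scatter). Chloro itself has not been measured, so a modest fall in this assay is expected, close to the scatter and possibly within it.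

The expected step is a number 8.3 percentage points lower from compound 3 to compound 4 (within the scatter).

For compound 4 the estimated value is 73%, with an expected range of 62% to 85%.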

Compound 4, percent growth inhibition at one concentration: 76.6%
Estimate against measurement, compound 4: 3.6 percentage points below; the range from low to high includes it.
By their numbers in this assay, from the lowest: compounds 2, 4, 3 and 1 (each within the scatter of the next, the first and the last beyond it).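

In this assay all three new steps stay within the scatter, namely a number 4.7 percentage points lower from compound 3 to compound 4 (within the scatter) and a number 8.9 percentage points higher from compound 2 to compound 4 (within the scatter) and a number 7.4 percentage points lower from compound 1 to compound 4 (within the scatter) on this read-out. The 4-chlorophenyl group on the sulfur therefore cannot be told apart from phenethyl here, and chloro on the aromatic carbon cannot be told apart from either bromo or methyl, even though the exchange of those two gives a number 16.3 percentage points lower from compound 1 to compound 2 (beyond the scatter) in the earlier pair. Nothing at hand explains any of these steps.

The compounds shown carry only aryl and phenethyl groups on the sulfur, so an amine, a carboxylic acid or a chain longer than phenethyl at this place remains open. Also open, as far as these compounds go, is whether these readings at a single concentration would hold at other concentrations.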